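Ester shortening at the hydroxy ester arm of the core

The source may report more compounds than this note shows. Statements on the series, on what has been measured and on what is new or still open speak of the compounds shown alone.

compound 1 `C/C=C(\C)C(=O)O[C@H]1[C@]2(C)C[C@@H]3O[C@@]1(O)C=C1C4=CC(=O)O[C@@H](c5ccoc5)[C@]4(C)CC[C@@H]1[C@]3(C)[C@@H]2[C@@H](O)C(=O)OC`: > 100000 nM
compound 2 `CCOC(=O)[C@H](O)[C@@H]1[C@@]2(C)C[C@@H]3O[C@@](O)(C=C4C5=CC(=O)O[C@@H](c6ccoc6)[C@]5(C)CC[C@@H]4[C@@]31C)[C@H]2O`: > 100000 nM

Both shown entries in a functional assay on HeLa cells (Homo sapiens) for inhibition, read by MTT assay, with a stated time of 24 h (a lower number here means a stronger inhibitor, a higher number a weaker inhibitor), are limits, not numbers. Compound 1 gives > 100000 nM, a limit of this assay. Compound 2 gives > 100000 nM, likewise a limit. Compound 2 therefore stands at the edge of what this assay reports, where both values sit (the limit of > 100000 nM in this assay, at which 2 of the 2 values shown sit).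

Compound 3 `COC(=O)[C@H](O)[C@@H]1[C@@]2(C)C[C@@H]3O[C@@](O)(C=C4C5=CC(=O)O[C@@H](c6ccoc6)[C@]5(C)CC[C@@H]4[C@@]31C)[C@H]2O` is not yet measured and differs from compound 2 by hydrogen in place of methyl on a saturated chain carbon bound to an oxygen next to a carbonyl group. Within the data shown here, no measured step of this kind is available. A step that the limit leaves unreadable from compound 2 to compound 3 is expected, none beyond the scatter. Compound 3 is expected to give 150000 nM (range 50000 nM to 500000 nM), most probably again as a limit.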

Compound 3, half-maximal inhibitory concentration: > 100000 nM
Compound 3 gave a limit, no number (the forecaster's own chance of this, stated with the estimate: 85%); the middle value does not contradict the limit.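

No step can be read from compound 1 or compound 2 to compound 3 in this assay, all three values being limits: the limit of > 100000 nM in this assay, at which 3 of the 3 values shown sit.

Left open is whether either change alters inhibition at all, and how strongly any of these compounds inhibits.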